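Chromene chalcones: phenyl to pyridin-2-yl on the enone

The source may report more compounds than this note shows. Statements on the series, on what has been measured and on what is new or still open speak of the compounds shown alone.

In a functional assay on HepG2 cells (Homo sapiens) for antiproliferative activity, read by MTT assay, with a stated time of 24 h (a lower number here means a stronger inhibitor, a higher number a weaker inhibitor), compound 1 `COc1ccc(/C=C/C(=O)c2ccc(OC)c3c2OC(C)(C)C=C3)c(F)c1` gives 7560 nM
In this assay compound 2 `COc1ccc(C(=O)/C=C/c2ccc([N+](=O)[O-])cc2)c2c1C=CC(C)(C)O2` gives 2610 nM
In this assay compound 3 `COc1ccc(C(=O)/C=C/c2ccccc2)c2c1C=CC(C)(C)O2` gives > 10000 nM

Compound 3 carries a plain phenyl on the enone chain. Its value in this assay is a limit of the assay, not a number, so only a range for it is known: it sits at the floor of potency among these three, at the limit of > 10000 nM in this assay, at which 1 of the 3 values shown sits. The two measured steps that reach compound 3 both move in the weaker direction: an at least 1.3-fold higher number from compound 1 to compound 3 (0.12 log units; that floor lies within the scatter), and an at least 3.8-fold higher number from compound 2 to compound 3 (0.58 log units; beyond the scatter), the latter beyond the scatter and therefore a real loss when the nitro is removed.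

Compound 4 `COc1ccc(C(=O)/C=C/c2ccccn2)c2c1C=CC(C)(C)O2` differs from compound 3 in one place: pyridin-2-yl in place of phenyl on a double-bonded chain carbon bound to a double-bonded chain carbon. For the measured compounds named here, no measured step in this set exchanges a ring carbon for a ring nitrogen, so the direction of the change is unsupported by data; the only bearing steps say that compound 3 is already at or beyond the limit. Compound 4 is therefore expected to stay near that limit, with a number no higher from compound 3 to compound 4 (the limit leaves the size open) as the most likely outcome. The estimate for compound 4 in this assay is 10000 nM, with a range from 3500 nM to 30000 nM.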

Compound 4, half-maximal inhibitory concentration: 5760 nM
Beside the measured number, compound 4's estimate is 1.7-fold (0.24 log units) above it; low and high end bracket the measured number.
By their numbers in this assay, from the lowest: compound 2; then compounds 4 and 1 (each within the scatter of the next). At a limit, above all of these: compound 3.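

At this place, on a double-bonded chain carbon bound to a double-bonded chain carbon, pyridin-2-yl gives a measured number in this assay, whereas compound 3, with phenyl, stands at a limit of the assay and not at a number: the limit of > 10000 nM in this assay, at which 1 of the 4 values shown sits.

On these data alone, the exchange of one ring carbon for a ring nitrogen therefore gives a step with only a floor (an at least 1.7-fold lower number from compound 3 to compound 4 (0.23 log units; that floor lies within the scatter)), so the direction is lower but its full size remains unknown. For the compounds shown here, the other two steps place pyridin-2-yl among the substituted rings: it is level with 2-fluoro-4-methoxyphenyl (a 1.3-fold lower number from compound 1 to compound 4 (0.12 log units; within the scatter)), while 4-nitrophenyl keeps a modest advantage over it (a 2.2-fold higher number from compound 2 to compound 4 (0.34 log units; beyond the scatter)), so on these four compounds a substituent on a phenyl ring is not the only change at this place that leaves the limit.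

As far as these compounds go, whether the gain belongs to the ring nitrogen alone or would carry over to other rings, such as pyrimidine or thiophene, remains open. Equally open, from the compounds shown here alone, is how an amine or a carboxylic acid on the pyridine ring would read at this place, and whether either could reach the level of 4-nitrophenyl.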